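The source may report more compounds than this note shows. Statements on the series, on what has been measured and on what is new or still open speak of the compounds shown alone.

Working notes on the coumarin-derived series in a functional assay on HUVEC cells (Homo sapiens) for inhibition, read by MTT assay, with a stated time of 24 h, tested at 10 uM; a higher number here means more inhibition of growth at the concentration tested, a lower number less inhibition of growth.

Compound 2 `COc1cc2ccc(=O)oc2cc1OCC(O)CN1CCN(C)CC1` gives 0.1% in this assay. Compound 3 `COc1cc2ccc(=O)oc2cc1OCCNC(C)C` gives 0.1%, level with compound 2 at the digits shown, and the two together stand lowest of the three numbers measured. Among the compounds with values here, compound 1 `COc1cc2ccc(=O)oc2cc1OCC(O)CN1CCCCC1` gives 31.4%, the highest of the three, and the single step of a number 31.3 percentage points lower from compound 1 to compound 2 (beyond the scatter) is beyond the scatter.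

Compound 4 `COc1cc2ccc(=O)oc2cc1OCC(O)CN1CCCC1` is not yet measured. Its difference from compound 2 is pyrrolidin-1-yl in place of 4-methylpiperazin-1-yl on a saturated chain carbon, two bonds along the chain from an oxygen on a saturated carbon. Within the data shown here, the only measured step that bears on this change is the one from compound 1 to compound 2, where the amine with one ring heteroatom gave way to the ring with two nitrogen atoms and the number fell by a number 31.3 percentage points lower from compound 1 to compound 2 (beyond the scatter). The change to compound 4 runs the other way, toward a ring with a single nitrogen, so a rise beyond the scatter is expected, though it need not recover the whole step because compound 1 carries 31.4% with a six-membered ring while compound 4 carries a five-membered one. The expected step is a number 19.9 percentage points higher from compound 2 to compound 4 (beyond the scatter). Compound 4 is estimated at 20%, with a range from 0% to 40%.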

Compound 4, percent growth inhibition at one concentration: 0.5%
Compound 4: middle estimate off by 19.5 percentage points, on the high side; low and high end bracket the measured number.
By their numbers in this assay, from the lowest: compounds 2, 3 and 4 (each within the scatter of the next); then compound 1.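

In this assay the exchange of 4-methylpiperazin-1-yl for pyrrolidin-1-yl gives a number 0.4 percentage points higher from compound 2 to compound 4 (within the scatter) and the exchange of piperidin-1-yl for pyrrolidin-1-yl gives a number 30.9 percentage points lower from compound 1 to compound 4 (beyond the scatter) at the same place, on a saturated chain carbon, two bonds along the chain from an oxygen on a saturated carbon. The large step seen earlier therefore cannot be tied to the second ring nitrogen alone: among these three rings, a ring with one nitrogen can read level with the ring with two, and only piperidin-1-yl stands apart. Nothing on hand explains the gap between the six-membered and five-membered rings.

The compounds shown leave open how an azepan-1-yl ring, a morpholin-4-yl ring or an open diethylamino group would read at this place. They also leave open whether a substituted piperidin-1-yl ring would keep the number of compound 1.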